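Two nucleosides at the limit, and a hexyl analogue to come

The compounds below may be only part of what the source reports. "The series", "measured", "known", "first", "only" and "open" are said of these compounds alone.

This account concerns cytotoxicity toward murine leukaemia cells, read in an ADME assay on L1210/0 cells (Mus musculus) for cytotoxicity, with a stated time of 48 h; on this read-out higher numbers stand for weaker inhibition and lower numbers for stronger inhibition. Compound 1, with the structure `O=c1ccn([C@@H]2C[C@H](CO)C[C@@H]2CO)c(=O)[nH]1`, was tested there. In this assay compound 1 gives > 200000 nM, which is a limit of the assay and not a number. Compound 2, with the structure `COCC#Cc1cn([C@H]2C[C@H](O)[C@@H](CO)O2)c(=O)[nH]c1=O`, was tested in the same way. In this assay compound 2 gives > 200000 nM, again a limit rather than a measured number. Thus both values shown sit at the limit of > 200000 nM in this assay, at which 2 of the 2 values shown sit, and compound 2 stands at that limit alongside compound 1, so no ordering between the two can be drawn.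

Compound 3, with the structure `CCCCCCc1cn([C@H]2C[C@H](O)[C@@H](CO)O2)c(=O)[nH]c1=O`, has not yet been measured. It differs from compound 2 in one place: hexyl in place of 3-methoxyprop-1-yn-1-yl on an aromatic carbon.

Among the compounds with values here, no step between measured compounds exists to guide the size of this change. Because compound 2 sits at the limit of > 200000 nM in this assay, at which 2 of the 2 values shown sit, the expectation is that compound 3 remains at the limit, with a step of a number no higher from compound 2 to compound 3 (the limit leaves the size open) amounting to none beyond the scatter. Compound 3 is therefore estimated at 200000 nM, with a range from 50000 nM to 800000 nM.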

Compound 3, half-maximal inhibitory concentration: > 200000 nM
Compound 3 ended at the assay's limit (the forecaster's own chance of this, stated with the estimate: 80%); the middle value sits exactly at the limit.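

No size can be read for the change from compound 2 to compound 3, because both stand at the same limit of the assay: the limit of > 200000 nM in this assay, at which 3 of the 3 values shown sit.

The compounds shown leave open how strongly any of them inhibits these cells, and whether hexyl and 3-methoxyprop-1-yn-1-yl differ at all in this assay.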